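The compounds below may be only part of what the source reports. "The series", "measured", "known", "first", "only" and "open" are said of these compounds alone.

In a functional assay on MCF7 cells (Homo sapiens) for antiproliferative activity, read by MTT assay, with a stated time of 72 h (a higher number here means a weaker inhibitor, a lower number a stronger inhibitor), the series has so far yielded no numerical value. Compound 1 (`CC1=CC[C@H]2[C@@H]1CC=C(C)[C@@H](CC[C@H]1[C@]3(C)CC[C@H](O)C(C)(C)O[C@H]3CC[C@@]1(C)O)C2(C)C`) reads > 50000 nM, which is a limit of the assay. Compound 2 (`CC1=CC[C@H]2[C@H](CC[C@]2(C)O)C(C)(C)[C@@H]1CC[C@H]1[C@]2(C)CC[C@H](OC(=O)c3ccc(C)cc3)C(C)(C)O[C@H]2CC[C@@]1(C)O`) reads > 50000 nM, which is also a limit. Compound 3 (`CC1=CC[C@H]2[C@@H]1CC=C(C)[C@@H](CC[C@H]1[C@]3(C)CC[C@H](OC(=O)c4ccncc4)C(C)(C)O[C@H]3CC[C@@]1(C)O)C2(C)C`) reads > 50000 nM, again a limit. Compound 2 therefore has no number of its own, and neither of the other two compounds offers one for comparison: the limit of > 50000 nM in this assay, at which 3 of the 3 values shown sit.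

Compound 4 (`CC1=CC[C@H]2[C@H](CC[C@]2(C)O)C(C)(C)[C@@H]1CC[C@H]1[C@]2(C)CC[C@H](OC(=O)c3ccc(F)cc3)C(C)(C)O[C@H]2CC[C@@]1(C)O`) differs from compound 2 at one place: fluoro in place of methyl on an aromatic carbon. This puts fluoro in place of methyl on an aromatic carbon, para to a large group, so that 4-methylphenyl becomes 4-fluorophenyl.

Among the compounds with values here, no measured step covers this change. Within the data shown here, the only one available is a step that the two limits leave unreadable from compound 1 to compound 3, with (pyridin-4-yl)carbonyl in place of hydrogen on an oxygen on a saturated carbon. That step is a different change and has no size to carry over, so no step beyond the scatter is expected in this assay. The expected step is a step that the limit leaves unreadable from compound 2 to compound 4. A report as a limit is the likeliest outcome for the next reading. For compound 4 the estimated value is 60000 nM, with an expected range of 25000 nM to 150000 nM.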

Compound 4, half-maximal inhibitory concentration: 33500 nM
Estimate against measurement, compound 4: 1.8-fold (0.25 log units) above, within the range that was stated.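

In this assay, within the data shown here, compound 4 gives 33500 nM, the first numerical value, and it carries 4-fluorophenyl where compound 2 carries 4-methylphenyl. At this place, on an aromatic carbon para to a large group, fluoro in place of methyl reads as an at least 1.4-fold lower number from compound 2 to compound 4 (0.17 log units; that floor lies within the scatter), so the change has a lower bound on its size, but that bound alone does not clear the usual scatter. Compound 2 has no number of its own, so the true size of the step stays unknown and the other steps in the series cannot be read: the limit of > 50000 nM in this assay, at which 3 of the 4 values shown sit.

Open is how far the number at this place responds to the group on the aromatic carbon, since the compounds shown hold only methyl and fluoro there, and chloro, methoxy or an amine at the same carbon would test whether fluoro is special or whether the removal of methyl is enough. Also open is whether (4-fluorophenyl)carbonyl keeps a measurable value on the core of compound 1, where the only acylated example shown carries (pyridin-4-yl)carbonyl.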